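The compounds below may be only part of what the source reports. "The series", "measured", "known", "first", "only" and "open" are said of these compounds alone.

Going by the values given here, in an assay for inhibition of HSP60/HSP10 (Homo sapiens), with a stated time of 60 min (on this read-out lower numbers stand for stronger inhibition and higher numbers for weaker inhibition), compound 3 `O=C(Nc1ccc(Sc2nc3ccccc3s2)c(Cl)c1)c1cccc(Br)c1O` is the only compound with a measured number, giving 6900 nM. Compound 1 `COc1c(Br)cccc1C(=O)Nc1ccccc1` reaches only a limit of this assay, at > 100000 nM. Compound 2 `O=C(Nc1ccccc1)c1cc(Br)cc(Br)c1` likewise stops at a limit, at > 100000 nM. Two of the three values therefore stand at the limit of > 100000 nM in this assay, at which 2 of the 3 values shown sit, and compound 3 alone lies inside the range this assay can report. Compound 4 `O=C(Nc1ccc(Sc2nc3ccccc3s2)c(Cl)c1)c1ccccc1` differs from compound 3 by phenyl in place of 3-bromo-2-hydroxyphenyl on a carbonyl carbon. Among the compounds with values here, no measured pair shows this change on its own, so the expected step of a 4.3-fold higher number from compound 3 to compound 4 (0.64 log units; beyond the scatter) rests on the structural change alone and is expected to go toward weaker inhibition, beyond the usual scatter. Compound 4 is therefore estimated at 30000 nM, within 8000 nM to 100000 nM.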

Compound 4, half-maximal inhibitory concentration: > 100000 nM
Compound 4 ended at the assay's limit (the forecaster's own chance of this, stated with the estimate: 40%); middle value at least 3.3-fold (0.52 log units) from the limit.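

Phenyl in place of 3-bromo-2-hydroxyphenyl on a carbonyl carbon, with the rest of the molecule unchanged, gives an at least 14-fold higher number from compound 3 to compound 4 (1.16 log units; beyond the scatter). Going by these compounds alone, this is the first view of this position, and it shows that measurable inhibition here depends on the 3-bromo-2-hydroxyphenyl group. Compound 4 gives only a limit of the assay, not a number, so the true step may be larger: the limit of > 100000 nM in this assay, at which 3 of the 4 values shown sit.

On these data alone, the bromine and the hydroxy group leave together, so their separate shares in the loss stay open. As far as these compounds go, how an amine or a carboxylic acid in their place would fare also stays open.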